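The compounds below may be only part of what the source reports. "The series", "measured", "known", "first", "only" and "open" are said of these compounds alone.

Working notes on the series. Within the data shown here, compound 1 `Cc1nc(SCC(=O)Nc2nc(-c3ccc(Cl)cc3)cs2)n(Nc2ccccc2)c1C` is the only compound here with a number in a functional assay on SK-OV-3 cells (Homo sapiens) for antiproliferative activity, read by sulforhodamine B assay, with a stated time of 48 h; on this read-out higher numbers stand for lower toxicity in this test and lower numbers for higher toxicity in this test: compound 1 gives 47400 nM. The other value shown is a limit of the assay: compound 2 `Cc1ccc(Nn2c(SCC(=O)Nc3nc(-c4ccccc4)cs3)nc(C)c2C)cc1` returns > 100000 nM, a limit rather than a number, as the limit of > 100000 nM in this assay, at which 1 of the 2 values shown sits, records. Compound 3 `COc1ccc(Nn2c(SCC(=O)Nc3nc(-c4ccc(Cl)cc4)cs3)nc(C)c2C)cc1` is not yet measured; it differs from compound 1 by methoxy in place of hydrogen on an aromatic carbon, the rest of the core unchanged. Among the measured compounds shown here, no step between measured compounds is available. The expected step is therefore a 1.3-fold higher number from compound 1 to compound 3 (0.10 log units; within the scatter), a change within the scatter with no clear direction. Compound 3 is estimated at 60000 nM, between 20000 nM and 180000 nM.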

Compound 3, concentration lethal to 50% of the cells: > 100000 nM
Compound 3 gave a limit, no number (the forecaster's own chance of this, stated with the estimate: 45%); middle value at least 1.6-fold (0.22 log units) away from the limit.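

In this assay, the change from anilino to (4-methoxyphenyl)amino gives an at least 2.1-fold higher number from compound 1 to compound 3 (0.32 log units; beyond the scatter), so this position on the ring is not indifferent to substitution, and methoxy here goes with lower toxicity in this test. Compound 3 gives a limit, not a number, so the step has no upper end: the limit of > 100000 nM in this assay, at which 2 of the 3 values shown sit.

As far as these compounds go, whether fluorine, a hydroxyl or an amine at the same place would keep a measurable number remains open. From the compounds shown here alone, how large the methoxy step truly is also remains open.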